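A Hydroxy Replaces the Amide Group on a Shared Core

This account rests on a few compounds, and the source may have more. Where it says the series, first, only, none or still open, it means among the compounds named here.

Compound 2 `CC(=O)N(C)c1ccc(Nc2nccc(-c3cccnc3)n2)cc1` and compound 1 `CC1CCN(c2cccc(Nc3nccc(-c4cccnc4)n3)c2)CC1` share one core and were both tested in a functional assay for inhibition, with Homo sapiens as the target; a lower number here means a stronger inhibitor, a higher number a weaker inhibitor. Compound 2 gives 900 nM, the lower of the two numbers shown. Compound 1 gives 1200 nM, and the gap to compound 2 lies within the scatter, so the two cannot be ranked. Compound 3 `Oc1ccc(Nc2nccc(-c3cccnc3)n2)cc1` has not been measured. It differs from compound 2 by hydroxy in place of acetyl(methyl)amino on an aromatic carbon. Among the compounds with values here, no measured pair shows this change, so only a modest step in either direction is expected. Compound 3 is estimated at 1000 nM in this assay, with a range from 300 nM to 3500 nM. The expected step is a 1.1-fold higher number from compound 2 to compound 3 (0.05 log units; within the scatter).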

Compound 3, half-maximal inhibitory concentration: 5100 nM
The estimate for compound 3 lay 5.1-fold (0.71 log units) below the measured number, outside the stated range (above it).
By their numbers in this assay, from the lowest: compounds 2 and 1 (each within the scatter of the next); then compound 3.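

In this assay, within the data shown here, hydroxy in place of acetyl(methyl)amino on this aromatic carbon gives a 5.7-fold higher number from compound 2 to compound 3 (0.75 log units; beyond the scatter), so the group held here changes the number, which the earlier compounds could not show. Acetyl(methyl)amino thus cannot be exchanged freely for hydroxy at this position. Nothing available explains the size of this step.

On these data alone, it remains open whether the higher number reflects the absence of acetyl(methyl)amino or the presence of hydroxy. A methoxy group or an amine on the same carbon could separate these two readings.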